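This account rests on a few compounds, and the source may have more. Where it says the series, first, only, none or still open, it means among the compounds named here.

Measured compounds in an assay on CHO cells for displacement of a labelled ligand from prostaglandin E2 receptor EP4 subtype (Mus musculus), read by scintillation counting, with a stated time of 60 min; on this read-out higher numbers stand for weaker inhibition and lower numbers for stronger inhibition:

Compound 1, `O=C(O)CCCSCCN1C(=O)OC[C@@H]1/C=C/[C@@H](O)Cc1cccc(C(F)(F)F)c1`: 2 nM
Compound 2, `O=C(O)CCCSCCN1C(=O)SC[C@@H]1/C=C/[C@@H](O)Cc1cccc(C(F)(F)F)c1`: 0.97 nM
Compound 3, `COCc1cccc(C[C@H](O)/C=C/[C@H]2COC(=O)N2CCSCCCC(=O)O)c1`: 7.2 nM

Three compounds share a common arrangement and differ in two places. Compound 1 and compound 2 differ in their cores; the difference between the two cores is not broken down here. In this assay compound 2 gives 0.97 nM and compound 1 gives 2 nM, so compound 2 stands lowest of the three numbers, with the step to compound 1 beyond the scatter.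

Compound 3 carries the core of compound 1 and differs from it in one place, (methoxymethyl in place of trifluoromethyl on an aromatic carbon). This change gives a 3.6-fold higher number from compound 1 to compound 3 (0.56 log units; beyond the scatter).

Compound 4, `COCc1cccc(C[C@H](O)/C=C/[C@H]2CSC(=O)N2CCSCCCC(=O)O)c1`, is not yet measured. It carries the core of compound 2 and differs from it by methoxymethyl in place of trifluoromethyl on an aromatic carbon, the same change that turns compound 1 into compound 3, made at the same kind of place on the ring.

For the measured compounds named here, because the one measured example of this change, a 3.6-fold higher number from compound 1 to compound 3 (0.56 log units; beyond the scatter), lies beyond the scatter, a step of similar size is expected from compound 2 to compound 4, estimated as a 3.6-fold higher number from compound 2 to compound 4 (0.56 log units; beyond the scatter). On that basis compound 4 is expected to give about 3.5 nM in this assay. Going by the values given here, the estimate for compound 4 is expected to fall between 1.4 nM and 9 nM, since only one prior example of the change is available.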

Compound 4, inhibition constant: 1.2 nM
Compound 4: the middle estimate sits 2.9-fold (0.46 log units) above what was measured; measured number outside the range, below it.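

In this assay methoxymethyl in place of trifluoromethyl on the core of compound 2 gives a 1.2-fold higher number from compound 2 to compound 4 (0.09 log units; within the scatter) and so produces no change that can be told from repeat measurement on this core. Set beside the earlier result, the same change does not carry over at one size from the core of compound 1 to the core of compound 2: the same change on two cores in this assay, a 3.6-fold higher number (0.56 log units; beyond the scatter) from compound 1 to compound 3 and a 1.2-fold higher number (0.09 log units; within the scatter) from compound 2 to compound 4, 2.9-fold (0.46 log units) apart, beyond the scatter of two such steps. For the compounds shown here, this shows that, within these four compounds, the step measured on one core did not give the size of the step on the other, but with only one pair on each core it does not show why the two steps differ or whether a similar gap would appear for other changes or on other cores.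

The compounds shown leave open how other groups on that aromatic carbon, such as a nitrile, a methoxy group or a chlorine, would behave on the two cores, and whether those steps would also differ from core to core. They also leave open whether the gap would remain with an amide in place of the carboxylic acid or with a longer chain in place of the one that carries it.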